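From tert-butyl to bromo on an aromatic ring

The compounds below may be only part of what the source reports. "The series", "measured", "known", "first", "only" and "open" are said of these compounds alone.

Three compounds sharing one core, and differing in the aromatic group on the double-bonded chain, have been measured in a functional assay on PC-3 cells (Homo sapiens) for cytotoxicity, read by MTT assay, with a stated time of 48 h; on this read-out lower numbers stand for stronger inhibition and higher numbers for weaker inhibition. There, compound 1 `Cc1ccc(C)c(/C=C/[C@](C)(O)CC[C@@H]2[C@@]3(C)CCCC(C)(C)[C@@H]3CC[C@@]2(C)O)c1` gives 176 nM, compound 2 `CC1(C)CCC[C@]2(C)[C@@H](CC[C@@](C)(O)/C=C/c3cncc4ccccc34)[C@](C)(O)CC[C@@H]12` gives 3900 nM and compound 3 `CC(C)(C)c1ccc(/C=C/[C@](C)(O)CC[C@@H]2[C@@]3(C)CCCC(C)(C)[C@@H]3CC[C@@]2(C)O)cc1` gives 3800 nM. Compound 3 therefore sits at the high end of these numbers, level with compound 2: the result is a 1.0-fold lower number from compound 2 to compound 3 (0.01 log units; within the scatter), within the scatter. Against compound 1 the picture is a 22-fold higher number from compound 1 to compound 3 (1.33 log units; beyond the scatter), a large step.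

Compound 4 `CC1(C)CCC[C@]2(C)[C@@H](CC[C@@](C)(O)/C=C/c3ccc(Br)cc3)[C@](C)(O)CC[C@@H]12` changes one group of compound 3: bromo in place of tert-butyl on an aromatic carbon. In words, this is bromo in place of tert-butyl on an aromatic carbon, para to a large group.

Among the measured compounds shown here, no measured step makes this exact swap. The nearest guides are other changes of the aromatic group. The large 22-fold higher number from compound 1 to compound 2 (1.35 log units; beyond the scatter) shows that such a change can move the number strongly among these compounds, while the two high values show that different groups can also land together. For the measured compounds named here, the only lower value so far belongs to compound 1, at 176 nM, so a modest move downward is expected in this assay. The expected change is a 2.1-fold lower number from compound 3 to compound 4 (0.32 log units; beyond the scatter), and it remains uncertain. For compound 4 the estimated value is 1800 nM, with an expected range from 350 nM to 7000 nM.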

Compound 4, half-maximal inhibitory concentration: 41300 nM
Compound 4: the middle estimate sits 23-fold (1.36 log units) below what was measured; measured number outside the range, above it.
By their numbers in this assay, from the lowest: compound 1; then compounds 3 and 2 (each within the scatter of the next); then compound 4.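

Putting bromo in place of tert-butyl, on an aromatic carbon para to a large group, gives an 11-fold higher number from compound 3 to compound 4 (1.04 log units; beyond the scatter) in this assay, so this single swap, with the shared core untouched, is enough to weaken the result strongly. The 4-bromophenyl group also falls well behind the other aromatic groups, with an 11-fold higher number from compound 2 to compound 4 (1.02 log units; beyond the scatter) and a 230-fold higher number from compound 1 to compound 4 (2.37 log units; beyond the scatter), which makes compound 4 the weakest of the four. Compounds 2 and 3 stood level at the high end of the earlier numbers, but that level was no ceiling, and an aromatic group can push the number much higher. Nothing available here bears on what lies behind this loss of activity.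

With only tert-butyl and bromo compared at this aromatic carbon, the two compounds cannot tell whether the number follows bromo itself or the drop from four heavy atoms to one. A methoxy group, a chloro group or an amine at the same place would help separate these two readings.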